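Ester aryl swap: pyridin-4-yl replacing thiophen-2-yl

A few compounds are considered here, and "the series" means these few. Any claim that something is new, unique, unknown or untested is made for them only; others in the source may bear on it.

Three esters share one core and differ only in the aryl group on the carbonyl carbon. In an ADME assay on cells (Hepatocyte, Homo sapiens) for metabolic stability (a higher number here means that the compound lasts longer, a lower number that the compound disappears faster), compound 1 `O=C(OC1CCC(CN2CCN(c3cc(=O)c4cc(C(F)(F)F)cc([N+](=O)[O-])c4s3)CC2)CC1)c1ccco1` gives 0.075 h, compound 2 `O=C(OC1CCC(CN2CCN(c3cc(=O)c4cc(C(F)(F)F)cc([N+](=O)[O-])c4s3)CC2)CC1)c1ccc(F)cc1` gives 0.0983 h, and compound 3 `O=C(OC1CCC(CN2CCN(c3cc(=O)c4cc(C(F)(F)F)cc([N+](=O)[O-])c4s3)CC2)CC1)c1cccs1` gives 0.0917 h. Compound 3 sits level with both neighbours, since the step of a 1.2-fold higher number from compound 1 to compound 3 (0.09 log units; within the scatter) and the step of a 1.1-fold lower number from compound 2 to compound 3 (0.03 log units; within the scatter) both fall within the scatter, as does a 1.3-fold higher number from compound 1 to compound 2 (0.12 log units; within the scatter). Compound 4 `O=C(OC1CCC(CN2CCN(c3cc(=O)c4cc(C(F)(F)F)cc([N+](=O)[O-])c4s3)CC2)CC1)c1ccncc1` carries the change (pyridin-4-yl in place of thiophen-2-yl on a carbonyl carbon). Within the data shown here, every aryl exchange at this position so far left this assay unmoved, so for compound 4 the expected step is a 1.0-fold lower number from compound 3 to compound 4 (0.01 log units; within the scatter), none beyond the scatter. Compound 4 is therefore estimated at 0.09 h, between 0.045 h and 0.18 h.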

Compound 4, half-life: 0.075 h
For compound 4 the middle estimate is 1.2-fold (0.08 log units) above the measured one; low and high end bracket the measured number.
By their numbers in this assay, from the lowest: compounds 1, 4, 3 and 2 (each within the scatter of the next).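

In this assay the changes a 1.2-fold lower number from compound 3 to compound 4 (0.09 log units; within the scatter) and a 1.3-fold lower number from compound 2 to compound 4 (0.12 log units; within the scatter) and no change at the digits printed from compound 1 to compound 4 (within the scatter) all stay within the scatter. A six-membered aromatic ring carrying a ring nitrogen therefore leaves this position as flat as the earlier aryl exchanges did, and all four esters stand level. Nothing available explains why the number stays flat here.

All four groups on this carbonyl carbon are aromatic rings, so the compounds shown leave open whether an amine, a carboxylic acid or a longer alkyl chain there would move the number. They also leave open whether an amide in place of the ester would do so.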